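Amide-side variation toward thiophen-2-yl: notes on compound 3

The source may report more compounds than this note shows. Statements on the series, on what has been measured and on what is new or still open speak of the compounds shown alone.

Values in an assay on LtK cells with ATP-sensitive inward rectifier potassium channel 11 (Homo sapiens) as the target; a lower number here means that less compound is needed, a higher number that more compound is needed for the effect:
compound 1 `O=C(CCc1ccccc1)Nc1c(C(O)(C(F)(F)F)C(F)(F)F)ccc2ccccc12`: 1750 nM
compound 2 `O=C(Nc1c(C(O)(C(F)(F)F)C(F)(F)F)ccc2ccccc12)c1cccc([N+](=O)[O-])c1`: 117 nM

Within the data shown here, compound 2 holds the lower of the two numbers; the one measured step, a 15-fold lower number from compound 1 to compound 2 (1.17 log units; beyond the scatter), is the whole record so far. Compound 3 `O=C(Nc1c(C(O)(C(F)(F)F)C(F)(F)F)ccc2ccccc12)c1cccs1` differs from compound 2 in a single place: thiophen-2-yl in place of 3-nitrophenyl on a carbonyl carbon. Among the measured compounds shown here, that step bears on it only loosely, since it swapped an aliphatic chain for an aryl ring, whereas here one aryl ring replaces another and the nitro group departs; no measured pair isolates that. A modest rise in number is expected for compound 3, a 2.6-fold higher number from compound 2 to compound 3 (0.41 log units; beyond the scatter). Compound 3 is estimated at 300 nM, within 100 nM to 1000 nM.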

Compound 3, half-maximal effective concentration: 12 nM
Beside the measured number, compound 3's estimate is 25-fold (1.40 log units) above it; measured number below the stated range.
By their numbers in this assay, from the lowest: compound 3; then compound 2; then compound 1.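

In this assay, one aryl ring replacing another on the carbonyl carbon moves the number substantially (a 9.8-fold lower number from compound 2 to compound 3 (0.99 log units; beyond the scatter)), so the earlier gain from the aryl amide was not the whole effect at this position. The 3-nitrophenyl group is not required for a low number, and the full span from the phenethyl amide is wide (a 150-fold lower number from compound 1 to compound 3 (2.16 log units; beyond the scatter)). No supporting data explain this shift.

The compounds shown do not separate the loss of the nitro group from the arrival of the thiophen-2-yl ring. A plain phenyl or furan-2-yl group on the carbonyl carbon would bear on that question.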